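The source may report more compounds than this note shows. Statements on the series, on what has been measured and on what is new or still open speak of the compounds shown alone.

In a functional assay on HL-60 cells (Homo sapiens) for cytotoxicity, read by luminescence and CellTiter-Glo, with a stated time of 3 days (a higher number here means a weaker inhibitor, a lower number a stronger inhibitor), compound 2 `N#Cc1ccc(NC(=O)c2ccc(-c3cccnc3)cc2O)cc1` gives 6660 nM, the highest of the two numbers available. Compound 1 `N#Cc1ccc(NC(=O)c2ccc3cccnc3c2O)c(Cl)c1` gives 910 nM in this assay, a lower number that lies beyond the usual scatter. Compound 3 `N#Cc1ccc2nc(-c3ccccc3O)[nH]c2c1` reaches only a limit in this assay, > 10000 nM. This is the limit of > 10000 nM in this assay, at which 1 of the 3 values shown sits.

The step now considered leads to compound 4 `COc1ccc(C(=O)Nc2ccc(C#N)cc2)c(O)c1`, which has not yet been measured in this assay. It differs from compound 2 in one place: methoxy in place of pyridin-3-yl on an aromatic carbon. The group that leaves carries one six-membered aromatic ring with 1 hetero atom; the methoxy that enters has no ring. For the measured compounds named here, no measured pair among compounds 1, 2 and 3 shows a single change of this kind, so the size of the step has no direct precedent. For compound 4 the expected step is a 1.4-fold higher number from compound 2 to compound 4 (0.13 log units; within the scatter), a small move toward a weaker inhibitor. Compound 4 is therefore expected to give about 9000 nM in this assay, within a range from 2500 nM to 30000 nM, with a fair chance that only a limit is reported.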

Compound 4, half-maximal inhibitory concentration: 5470 nM
Estimate against measurement, compound 4: 1.6-fold (0.22 log units) above; measured number inside the range.
By their numbers in this assay, from the lowest: compound 1; then compounds 4 and 2 (each within the scatter of the next). At a limit, above all of these: compound 3.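

In this assay, putting methoxy in place of pyridin-3-yl on this aromatic carbon, meta to a hydroxy group and para to a large group, gives a 1.2-fold lower number from compound 2 to compound 4 (0.09 log units; within the scatter), so compounds 2 and 4 cannot be told apart. For the compounds shown here, this is the first single-place comparison in the set, and it shows that, for this pair, a six-membered aromatic ring and a small group with no ring give readings that match within the scatter. The data shown offer no measured property that would explain this result.

As far as these compounds go, this is one change at one position, so it remains open whether a different group here, such as an amine or a carboxylic acid, would shift the number beyond the scatter. From the compounds shown here alone, it also remains open whether the same swap would behave alike on a different core.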